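Swapping the bicyclic ring isomer on the lactam side chain

The source may hold more compounds than are shown below. What is called first, only, known or untested is meant among the compounds shown, and "the series" means these compounds.

Measured compounds:
- compound 1, `O=C1[C@@H](NS(=O)(=O)c2nc3cc(Cl)ccc3[nH]2)CCN1Cc1cc2c[nH]ccc-2n1`, giving 31% in an assay on isolated protein for inhibition of coagulation factor X (Oryctolagus cuniculus), tested at 1 uM; a higher number here means more inhibition at the concentration tested (going by the name of the read-out), a lower number less inhibition
- compound 2, `O=C1[C@@H](NS(=O)(=O)c2cc3cccnc3s2)CCN1Cc1cc2[nH]cccc-2n1`, giving 44% in this assay
- compound 3, `O=C1[C@@H](NS(=O)(=O)c2ccc(-c3ccon3)s2)CCN1Cc1cc2[nH]cccc-2n1`, giving 31% in this assay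

Compound 2 stands highest of the three numbers, with compound 1 and compound 3 each lying beyond the scatter below it. Within the data shown here, the one measured step changes the group on the sulfonyl sulfur: a number 13 percentage points lower from compound 2 to compound 3 (beyond the scatter). Compound 4, `O=C1[C@@H](NS(=O)(=O)c2cc3cccnc3s2)CCN1Cc1cc2c[nH]ccc-2n1`, keeps that sulfonyl group of compound 2 and instead rearranges the group on the saturated chain carbon bound to an amide-type nitrogen in a ring: a group of 9 heavy atoms (7 carbon, 2 nitrogen; one five-membered aromatic ring with 1 hetero atom, one six-membered aromatic ring with 1 hetero atom) in place of a group of 9 heavy atoms (7 carbon, 2 nitrogen; one five-membered aromatic ring with 1 hetero atom, one six-membered aromatic ring with 1 hetero atom), on a saturated chain carbon bound to an amide-type nitrogen in a ring. Among the measured compounds shown here, no measured step touches this side of the molecule in isolation, so the step from compound 2 to compound 3 does not bear on it. Compound 1 carries the same rearranged ring as compound 4 but differs from compound 2 in two places, so its value shows only that the combination there sits lower. With no direct guide, the estimate leans on compound 2 with a modest expected drop: a number 9 percentage points lower from compound 2 to compound 4 (within the scatter). Compound 4 is therefore estimated at 35%, in a range from 15% to 55%.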

Compound 4, a percentage reported as inhibition, at one concentration (the size of the read-out at that concentration, not a potency): 18%
Compound 4: middle estimate off by 17 percentage points, on the high side, and the stated range covers the measured number.
By their numbers in this assay, from the lowest: compound 4; then compounds 1 and 3 (each within the scatter of the next); then compound 2.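

Joining the same atoms differently, in a group on a saturated chain carbon bound to an amide-type nitrogen in a ring, gives a number 26 percentage points lower from compound 2 to compound 4 (beyond the scatter) in this assay even though the counts of heavy atoms, hydrogen-bond donors and acceptors stay the same, so this position responds to the arrangement of the ring atoms and not only to their number. With the rearranged group held fixed, the group on the sulfonyl sulfur still matters, as the change gives a number 13 percentage points lower from compound 1 to compound 4 (beyond the scatter) and shows that this second position also moves the number. Nothing available explains why the arrangement of ring atoms matters here.

On these data alone, whether the drop from the rearrangement also appears with the sulfonyl group of compound 3 remains open. So does how a plain phenyl ring or an amine would compare at the saturated chain carbon.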